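From a Methylphenyl Urea to a Chlorophenyl Urea

The compounds below may be only part of what the source reports. "The series", "measured", "known", "first", "only" and "open" are said of these compounds alone.

Of the compounds shown here, three built on one shared core have been tested in a functional assay on cells (T-cell, Mus musculus) for inhibition; a higher number here means a weaker inhibitor, a lower number a stronger inhibitor. Compound 1 `COc1cc(/C=C/C(=O)Nc2ccc3c(c2)COC3=O)ccc1OC(C)=O` gives 136 nM. Compound 2 `CC(C)c1ccc(/C=C/C(=O)Nc2ccc3c(c2)COC3=O)cc1` gives 1590 nM. Compound 3 `Cc1ccccc1NC(=O)Nc1ccc2c(c1)COC2=O`, a urea, gives 900 nM. Among these three numbers compound 3 stands second highest: its gap to compound 2 lies within the usual scatter, so no order between those two can be read, while compound 1 sits clearly lower, beyond the scatter.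

Compound 4 `O=C(Nc1ccc(Cl)cc1)Nc1ccc2c(c1)COC2=O` is not yet measured. It differs from compound 3 in one place only: 4-chlorophenyl in place of 2-methylphenyl on an amide-type nitrogen. Among the compounds with values here, no measured pair shows what such a swap does on this core, so the expected step from compound 3 to compound 4 in this assay is a modest one, leaning toward a lower number, estimated as a 1.5-fold lower number from compound 3 to compound 4 (0.18 log units; within the scatter). On that basis compound 4 is expected to come in near 600 nM, with a plausible range from 150 nM to 2500 nM.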

Compound 4, half-maximal inhibitory concentration: 2450 nM
Beside the measured number, compound 4's estimate is 4.1-fold (0.61 log units) below it; measured number inside the range.
By their numbers in this assay, from the lowest: compound 1; then compounds 3, 2 and 4 (each within the scatter of the next, the first and the last beyond it).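

In this assay, within the data shown here, the change of 2-methylphenyl to 4-chlorophenyl on the amide-type nitrogen gives a 2.7-fold higher number from compound 3 to compound 4 (0.43 log units; beyond the scatter), the first single-change step on this core, and it shows that the group at this position can shift the number. The two groups match in heavy atoms, hydrogen-bond donors, hydrogen-bond acceptors and net charge, so these counts alone do not predict the result. Nothing available explains the direction or size of this step.

From the compounds shown here alone, the swap alters both the substituent and where it sits on the ring, so the share of each remains open. A 2-chlorophenyl or 4-methylphenyl group would separate the two, while a plain phenyl group would show how either substituent compares with none.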